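Aryl variation on the benzylamine arm: compound 4

This account rests on a few compounds, and the source may have more. Where it says the series, first, only, none or still open, it means among the compounds named here.

Compound 3 `O=C(O)CCc1ccc(NCc2ccccc2)cc1` gives 144% in a functional assay on CHO cells for agonist activity at Free fatty acid receptor 1 (Homo sapiens), read by reporter gene assay; a higher number here means a larger maximal response, a lower number a smaller maximal response. Compound 1 `O=C(O)CCc1ccc(NCc2ccc(Cl)s2)cc1` gives 143%, and compound 2 `O=C(O)CCc1ccc(NCc2ccc(C(F)(F)F)cc2)cc1` gives 133%. For the measured compounds named here, compound 3 thus carries the largest of the three values, but the step of a number 1 percentage points higher from compound 1 to compound 3 (within the scatter) lies within the scatter, so compound 1 and compound 3 cannot be told apart; only the step of a number 11 percentage points higher from compound 2 to compound 3 (beyond the scatter) is beyond the scatter, and it is modest.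

Compound 4 `O=C(O)CCc1ccc(NCc2cccnc2)cc1` is not yet measured. The change is pyridin-3-yl in place of phenyl on a saturated chain carbon bound to a nitrogen on an aromatic ring. Neither measured step concerns this kind of change: the step from compound 1 to compound 3 swaps one aromatic ring for another and stays within the scatter, while the step from compound 2 to compound 3 removes a substituent. Both steps keep the maximal response within a narrow band, so for compound 4 no step beyond the scatter is expected in this assay, and the estimated step of a number 6 percentage points lower from compound 3 to compound 4 (within the scatter) is small. Compound 4 is expected to reach about 138%, with a range from 120% to 155%.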

Compound 4, largest response reached (reported as percent of maximum), in percent of the reference or control that the assay uses: 4%
Beside the measured number, compound 4's estimate is 134 percentage points above it, and the stated range ends above it.
By their numbers in this assay, from the lowest: compound 4; then compounds 2, 1 and 3 (each within the scatter of the next, the first and the last beyond it).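

In this assay, the aromatic ring at this place is not freely interchangeable: the step of a number 140 percentage points lower from compound 3 to compound 4 (beyond the scatter) and the step of a number 139 percentage points lower from compound 1 to compound 4 (beyond the scatter) show that the maximal response can collapse, although the exchange of 5-chlorothiophen-2-yl for phenyl between compound 1 and compound 3 stayed within the scatter. Between compound 3 and compound 4, the counted change is small: the heavy-atom count stays the same, while one ring carbon gives way to nitrogen and one hydrogen-bond acceptor enters. No measurement at hand accounts for the loss.

The compounds shown leave open whether the loss is specific to pyridin-3-yl or extends to pyridin-2-yl, pyridin-4-yl or pyrimidin-5-yl at this place. They also leave open whether a chloro or methyl group on the pyridin-3-yl ring would restore the response.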